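This account rests on a few compounds, and the source may have more. Where it says the series, first, only, none or still open, it means among the compounds named here.

In an ADME assay on microsomes from liver (Rattus norvegicus) for metabolic stability (a lower number here means that the compound disappears faster, a higher number that the compound lasts longer), compound 1 `COc1cc(OCc2csc(-c3ccc(C(F)(F)F)cc3)n2)c2cc(-c3cn4nc(OC)sc4n3)oc2c1` gives 1.42 h and compound 2 `COc1cc(OCc2csc(-c3ccc(S(C)(=O)=O)cc3)n2)c2cc(-c3cn4nc(OC)sc4n3)oc2c1` gives 1.12 h, so compound 2 stands level with compound 1 within the scatter. Compound 3 `COc1cc(OCc2csc(-c3ccc(C(=O)O)cc3)n2)c2cc(-c3cn4nc(OC)sc4n3)oc2c1` carries carboxy in place of methylsulfonyl on an aromatic carbon. Among the measured compounds shown here, the one measured step at this place, a 1.3-fold lower number from compound 1 to compound 2 (0.10 log units; within the scatter), stayed within the scatter, though no measured compound yet carries carboxy. A change beyond the scatter is therefore not expected, and the expected step is a 1.2-fold higher number from compound 2 to compound 3 (0.06 log units; within the scatter). Compound 3 is estimated at 1.3 h, with an expected range of 0.6 h to 3 h.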

Compound 3, half-life: > 2 h
Compound 3 gave a limit, no number (the forecaster's own chance of this, stated with the estimate: 10%); middle value at least 1.5-fold (0.18 log units) from the limit.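

For compound 3, > 2 h is a limit of the assay and not a number. Even so, carboxy on this aromatic carbon brings no loss in this assay, with an at least 1.7-fold higher number from compound 2 to compound 3 (0.25 log units; that floor lies within the scatter) and an at least 1.4-fold higher number from compound 1 to compound 3 (0.14 log units; that floor lies within the scatter). This place, where the two earlier groups stood level, therefore also accepts a group with a hydrogen-bond donor, although neither floor clears the scatter on its own.

As far as these compounds go, the true size of the rise stays open, since the reading stops at a limit: the limit of > 2 h in this assay, at which 1 of the 3 values shown sits. Whether an amide or an amine at this place would behave like carboxy also stays open.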